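This account rests on a few compounds, and the source may have more. Where it says the series, first, only, none or still open, it means among the compounds named here.

Of the compounds shown here, two have been measured in an assay on cells for antagonist activity at transient receptor potential cation channel subfamily V member 1 (Homo sapiens), read by FLIPR and calcium flux, with a stated time of 6 min; a higher number here means a weaker inhibitor, a lower number a stronger inhibitor: compound 1 `CCCCOc1nc(C(C)(C)C)ccc1CNC(=O)C(C)c1ccc(NS(C)(=O)=O)c(F)c1` gives 0.9 nM, and compound 2 `CC(C(=O)NCc1ccc(C(C)(C)C)cc1N1CCCCC1)c1ccc(NS(C)(=O)=O)c(F)c1` gives 1.9 nM. Compound 2 thus holds the higher of the two numbers, and its gap to compound 1 lies beyond the scatter. Compound 3 `CC(C)CCOc1cc(C(C)(C)C)ccc1CNC(=O)C(C)c1ccc(NS(C)(=O)=O)c(F)c1` differs from compound 2 by isopentyloxy in place of piperidin-1-yl on an aromatic carbon. Within the data shown here, no measured pair shows a step of this kind, so the direction rests on the two numbers alone. The step of a 1.6-fold lower number from compound 2 to compound 3 (0.20 log units; within the scatter) is expected to be small and downward in this assay, hardly beyond the scatter. Compound 3 is estimated at 1.2 nM, within 0.4 nM to 4 nM.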

Compound 3, inhibition constant: 0.6 nM
Beside the measured number, compound 3's estimate is 2.0-fold (0.30 log units) above it; the measured number falls inside the stated range.
By their numbers in this assay, from the lowest: compounds 3 and 1 (each within the scatter of the next); then compound 2.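

On this aromatic carbon, ortho to a large group and meta to a tert-butyl group, isopentyloxy in place of piperidin-1-yl gives a 3.2-fold lower number from compound 2 to compound 3 (0.50 log units; beyond the scatter) in this assay. The position therefore accepts an open chain as well as the six-membered ring, and the number moves down rather than up with the change. Nothing measured here explains this step.

Going by these compounds, what stays open is whether the ether oxygen or the open chain accounts for the step. Also open, on these data alone, is how a shorter chain such as ethoxy, or a cyclic ether such as cyclopentyloxy, would read at this carbon.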